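Swapping a Methylphenyl for a Chlorophenyl on a Shared Core

This account rests on a few compounds, and the source may have more. Where it says the series, first, only, none or still open, it means among the compounds named here.

Three compounds built on one shared core have been examined in an ADME assay on HepG2 cells (Homo sapiens) for cytotoxicity, read by sulforhodamine B assay, with a stated time of 48 h; a higher number here means that more compound is tolerated, a lower number that less compound is tolerated. Compound 1 `COc1ccc(-c2nc(/C=C/c3cc4ccccc4nc3OC)no2)cc1` carries a 4-methoxyphenyl group, and in this assay compound 1 gives > 220000 nM, which is a limit of the assay rather than a measured number. Compound 2 `COc1nc2ccccc2cc1/C=C/c1noc(-c2ccc(Br)cc2)n1` carries a 4-bromophenyl group, and compound 2 gives > 195000 nM, again a limit. Compound 3 `COc1nc2ccccc2cc1/C=C/c1noc(-c2ccccc2C)n1` carries a 2-methylphenyl group, and compound 3 gives > 230000 nM, also a limit.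

Compound 3 therefore stands alongside the other two at the ceiling of what the assay reports; none of the three can be ranked against the others. The steps a step that the two limits leave unreadable from compound 1 to compound 2, a step that the two limits leave unreadable from compound 1 to compound 3 and a step that the two limits leave unreadable from compound 2 to compound 3 are each left unreadable by the two limits at their ends.

The next change is 3-chlorophenyl in place of 2-methylphenyl on an aromatic carbon, giving compound 4 `COc1nc2ccccc2cc1/C=C/c1noc(-c2cccc(Cl)c2)n1`. All three measured steps bear on this change, and none of them revealed any readable movement. The expectation is that compound 4 also sits at the limit, with the step of a number no higher from compound 3 to compound 4 (the limit leaves the size open) estimated as nothing beyond the scatter. Compound 4 is estimated at 230000 nM, with a range from 150000 nM to 400000 nM.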

Compound 4, half-maximal cytotoxic concentration: > 220000 nM
Compound 4: no number, only a limit; the forecaster's own chance of this, stated with the estimate: 85%; the middle value does not contradict the limit.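

In this assay compound 4 gives > 220000 nM, which is a limit of the assay and not a number. Its steps from compound 1, compound 2 and compound 3 cannot be read. The compounds shown leave open where the actual cytotoxic concentration of each lies, and so whether changing the aromatic group on the shared core shifts it at all.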